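Chloro for methyl on two related cores

This account rests on a few compounds, and the source may have more. Where it says the series, first, only, none or still open, it means among the compounds named here.

Three compounds have been measured so far in a functional assay on the whole organism for antagonist activity, with Mus musculus as the target, in the maximal electroshock model; a higher number here means that more compound is needed for the effect, a lower number that less compound is needed:

compound 1, `COC(=O)NC1=NC(c2ccccc2C)CN1`, giving 55 mg/kg
compound 2, `COC(=O)NC1=NC(c2ccccc2Cl)CN1`, giving 50 mg/kg
compound 3, `COC(=O)NC1=NC(c2cccc(C)c2)CN1C`, giving 89 mg/kg

Compound 1 and compound 2 differ in a single place: chloro in place of methyl on an aromatic carbon. In this assay that change made a 1.1-fold lower number from compound 1 to compound 2 (0.04 log units; within the scatter). Compound 4, `COC(=O)NC1=NC(c2cccc(Cl)c2)CN1C`, has not yet been measured; it stands to compound 3 as compound 2 stands to compound 1, the difference being (chloro in place of methyl on an aromatic carbon). The difference between the core of compound 1 and the core of compound 3 is not broken down here. The two exchanges are the same kind of change rather than the same change, since in compound 1 the exchanged group sits ortho to a large group, whereas in compound 3 it sits meta to a large group. Among the compounds with values here, on the strength of the one earlier instance, where the step was a 1.1-fold lower number from compound 1 to compound 2 (0.04 log units; within the scatter), a small step is expected here as well, namely a 1.1-fold lower number from compound 3 to compound 4 (0.05 log units; within the scatter). In this assay compound 4 is therefore estimated at 80 mg/kg, with the expected range running from 45 mg/kg to 150 mg/kg.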

Compound 4, dose for half-maximal effect: 100 mg/kg
For compound 4 the middle estimate is 1.3-fold (0.10 log units) below the measured one; the measured number falls inside the stated range.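

In this assay, chloro in place of methyl on an aromatic carbon, meta to a large group, gave a 1.1-fold higher number from compound 3 to compound 4 (0.05 log units; within the scatter). Set beside the earlier instance, the exchange reads alike on the two cores, with each step and the gap between them inside the usual scatter: the same change on two cores in this assay, a 1.1-fold lower number (0.04 log units; within the scatter) from compound 1 to compound 2 and a 1.1-fold higher number (0.05 log units; within the scatter) from compound 3 to compound 4, 1.2-fold (0.09 log units) apart, within the scatter of two such steps. Within the data shown here, this shows that the exchange made no change beyond the scatter on either core, but it does not show how a sizeable effect would carry from one core to another, as neither step is large, only two cores are represented, and the exchanged group does not stand at the same place in both.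

The compounds shown leave open whether other groups meta to a large group, such as methoxy, a nitrile or an amine, would give a step beyond the scatter in this assay. They also leave open what the same exchange would do on the core of compound 1 with the group meta to a large group, which would separate the place on the ring from the core.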